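Sulfonyl for carbamoyl on a shared aminothienopyridine-type core

A few compounds are considered here, and "the series" means these few. Any claim that something is new, unique, unknown or untested is made for them only; others in the source may bear on it.

Two measured compounds carry a butylsulfinyl group on the shared core: compound 1 `CCCC[S+]([O-])c1sc2nc(-c3nccs3)cc(-c3ccc(C(C)(C)O)cc3)c2c1N` and compound 2 `CCCC[S+]([O-])c1sc2nc(-c3nccs3)cc(-c3nccs3)c2c1N`. Within the data shown here, in an assay for inhibition of 15-hydroxyprostaglandin dehydrogenase [NAD(+)] (Homo sapiens), read by fluorescence, with a stated time of 15 min, in the presence of a further agent that is not named here (a lower number here means a stronger inhibitor, a higher number a weaker inhibitor), compound 1 gives 3.6 nM, and compound 2 gives 1.8 nM; the step of a 2.0-fold lower number from compound 1 to compound 2 (0.30 log units; within the scatter) is the only measured step here. Compound 3 `CCCNC(=O)c1sc2nc(-c3cccs3)cc(-c3ccccc3)c2c1N` carries a propylcarbamoyl group instead. In this assay compound 3 reaches only a limit of the assay, > 7500 nM, which is the limit of > 7500 nM in this assay, at which 1 of the 3 values shown sits. Compound 4 `CCCCS(=O)(=O)c1sc2nc(-c3cccs3)cc(-c3ccccc3)c2c1N` is unmeasured and differs from compound 3 in one place: butylsulfonyl in place of propylcarbamoyl on an aromatic carbon. Among the measured compounds shown here, no measured step concerns this exchange; the single measured step, from compound 1 to compound 2, changes a different part of the molecule and lies within the scatter. What the numbers do show is that both butylsulfinyl compounds sit at low values while the propylcarbamoyl compound sits at a limit. Compound 4 is therefore expected to give 30 nM, within a range from 3 nM to 300 nM. The expected number amounts to a step of an at least 250-fold lower number from compound 3 to compound 4 (2.39 log units; beyond the scatter).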

Compound 4, half-maximal inhibitory concentration: 25 nM
Compound 4: the middle estimate sits 1.2-fold (0.08 log units) above what was measured; low and high end bracket the measured number.
By their numbers in this assay, from the lowest: compounds 2 and 1 (each within the scatter of the next); then compound 4. At a limit, above all of these: compound 3.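

In this assay, butylsulfonyl in place of propylcarbamoyl on an aromatic carbon of the five-membered aromatic ring gives an at least 300-fold lower number from compound 3 to compound 4 (2.47 log units; beyond the scatter). Among these compounds, compound 3 and compound 4 differ in this one place only, so the step ties the large change to this position, which the earlier compounds could not do: each of them differs from compound 3 in more than one place. The step has only a lower bound on its size, because compound 3 stands at a limit and not at a number: the limit of > 7500 nM in this assay, at which 1 of the 4 values shown sits.

The exchange alters the linking group and the chain together, so the compounds shown do not separate the two. From the compounds shown here alone, a propylsulfonyl or butylcarbamoyl group would divide them, and it remains open how a carboxylic acid or an amine at this position would read.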